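The source may hold more compounds than are shown below. What is called first, only, known or untested is meant among the compounds shown, and "the series" means these compounds.

Within the data shown here, in a functional assay on MCF7 cells (Homo sapiens) for antiproliferative activity, read by MTT assay, with a stated time of 48 h (a lower number here means a stronger inhibitor, a higher number a weaker inhibitor), compound 1 `COc1ccc2nc(NC(c3cn(-c4ccccc4)nc3-c3ccc(F)cc3)c3c(O)ccc4ccccc34)sc2c1` gives 16900 nM, the lower of the two numbers so far, while compound 2 `COc1cccc(-c2nn(-c3ccccc3)cc2C(Nc2nc3ccc(OC)cc3s2)c2c(O)ccc3ccccc23)c1` gives 62600 nM. Compound 3 `Oc1ccc2ccccc2c1C(Nc1nc2ccc(Cl)cc2s1)c1cn(-c2ccccc2)nc1-c1ccc(F)cc1` is not yet measured. It carries chloro in place of methoxy on an aromatic carbon, so 6-methoxy-1,3-benzothiazol-2-yl becomes 6-chloro-1,3-benzothiazol-2-yl (chloro in place of methoxy on an aromatic carbon). Among the measured compounds shown here, no measured pair tests this change. For the measured compounds named here, the only measured step, a 3.7-fold higher number from compound 1 to compound 2 (0.57 log units; beyond the scatter), is a modest one at a different place, replacing 4-fluorophenyl with 3-methoxyphenyl. It gives a rough idea of size for a single change in this series, but no direction for this one. The working expectation is therefore no step beyond the scatter, with a modest move either way still possible. The estimated step reads a 1.1-fold lower number from compound 1 to compound 3 (0.05 log units; within the scatter). In this assay the expected value for compound 3 is 15000 nM, within an estimated range of 6000 nM to 40000 nM.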

Compound 3, half-maximal inhibitory concentration: 21600 nM
Beside the measured number, compound 3's estimate is 1.4-fold (0.16 log units) below it; the range from low to high includes it.
By their numbers in this assay, from the lowest: compounds 1 and 3 (each within the scatter of the next); then compound 2.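

In this assay, among these compounds, the change from 6-methoxy-1,3-benzothiazol-2-yl to 6-chloro-1,3-benzothiazol-2-yl gives a 1.3-fold higher number from compound 1 to compound 3 (0.11 log units; within the scatter), the first reading at this position, and it does not separate the two groups. In this one pair, the methoxy with its oxygen, a hydrogen-bond acceptor, gives way to a single chlorine without a step beyond the scatter, whereas the change at the other place gives a 3.7-fold higher number from compound 1 to compound 2 (0.57 log units; beyond the scatter). No supporting evidence bears on why chloro and methoxy read alike here.

Two groups say little about the position as a whole, so an amine, a carboxylic acid or a longer alkoxy chain there could still shift the number in either direction. Also open, from the compounds shown here alone, is whether chloro reads the same when 3-methoxyphenyl stands in place of 4-fluorophenyl.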